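Swapping bromo for methoxy on a pendant phenyl ring

A few compounds are considered here, and "the series" means these few. Any claim that something is new, unique, unknown or untested is made for them only; others in the source may bear on it.

Compound 1 `COc1cc(OC)c(/C=C/S(=O)(=O)Cc2ccc(OC)c(N)c2)c(OC)c1` is the strongest of the three measured compounds: in a functional assay on DU-145 cells (Homo sapiens) for cytotoxicity, read by trypan blue exclusion, with a stated time of 96 h (a higher number here means a weaker inhibitor, a lower number a stronger inhibitor), compound 1 gives 4 nM. Compound 2 `COc1cc(OC)c(/C=C/S(=O)(=O)Cc2ccc(Br)c(N)c2)c(OC)c1` gives 750 nM in this assay. The two differ only by methoxy in place of bromo on an aromatic carbon, and that single change produced a 190-fold lower number from compound 2 to compound 1 (2.27 log units; beyond the scatter). Compound 3 `COC(=O)C(Nc1cc(CS(=O)(=O)/C=C/c2c(OC)cc(OC)cc2OC)ccc1OC)c1ccc(Br)cc1` carries a larger group on the ring nitrogen and gives 300 nM, so that a 75-fold higher number from compound 1 to compound 3 (1.88 log units; beyond the scatter). The difference between the cores of compound 3 and compound 2 is not broken down here.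

Compound 4 `COC(=O)C(Nc1cc(CS(=O)(=O)/C=C/c2c(OC)cc(OC)cc2OC)ccc1OC)c1ccc(OC)cc1` is not yet measured. It differs from compound 3 by methoxy in place of bromo on an aromatic carbon. This is the same kind of change as from compound 2 to compound 1, but not the same: there it sat ortho to an amino group on the core ring, whereas here it sits on the pendant ring with no amino group nearby. Because the earlier step of a 190-fold lower number from compound 2 to compound 1 (2.27 log units; beyond the scatter) was made in a different surrounding, only a more modest step is expected here, estimated as a 2.5-fold lower number from compound 3 to compound 4 (0.40 log units; beyond the scatter). Compound 4 is therefore expected to give about 120 nM, with a range from 25 nM to 600 nM.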

Compound 4, half-maximal inhibitory concentration: 250 nM
Beside the measured number, compound 4's estimate is 2.1-fold (0.32 log units) below it, within the range that was stated.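

On the large group carried by the ring nitrogen, going from 4-bromophenyl to 4-methoxyphenyl gives a 1.2-fold lower number from compound 3 to compound 4 (0.08 log units; within the scatter) in this assay, so the two cannot be told apart here. Methoxy in place of bromo therefore does not carry a fixed size of effect from one core to another in this series, as setting the two steps together shows: the same change on two cores in this assay, a 190-fold lower number (2.27 log units; beyond the scatter) from compound 2 to compound 1 and a 1.2-fold lower number (0.08 log units; within the scatter) from compound 3 to compound 4, 160-fold (2.19 log units) apart, beyond the scatter of two such steps

This does not show why the steps differ, since the two pairs differ both in which ring bears the change and in what sits on the nitrogen, and two pairs cannot separate these or support a general rule.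

The compounds shown leave open whether any other group at this spot, such as an amine or a chloro group, would give a number clearly apart from those of compound 3 and compound 4 in this assay. They also leave open what a carboxylic acid in place of the methoxycarbonyl group would do.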